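Methylsulfanyl in place of isopropoxy on compound 1

The source may report more compounds than this note shows. Statements on the series, on what has been measured and on what is new or still open speak of the compounds shown alone.

Compound 1 `COc1cc(-n2ncnc2-c2ccc(OC(C)C)cc2)cc(OC)c1OC` is the reference here. In a functional assay on Jurkat cells (Homo sapiens) for antiproliferative activity, read by MTT assay, with a stated time of 72 h (a higher number here means a weaker inhibitor, a lower number a stronger inhibitor), compound 1 gives 650 nM, the highest of the two numbers recorded. Compound 3 `COc1ccc(-n2ncnc2-c2cc(OC)c(OC)c(OC)c2)cc1` gives 93 nM in this assay. Compound 2 `COc1cc(-c2ncnn2-c2cccc(N)c2)cc(OC)c1OC` reaches > 10000 nM in this assay, which is a limit of the assay rather than a number (the limit of > 10000 nM in this assay, at which 1 of the 3 values shown sits). Among the compounds with values here, the only measured step, an at least 100-fold lower number from compound 2 to compound 3 (2.03 log units; beyond the scatter), concerns the group on the aromatic nitrogen and does not touch the position changed now. Compound 4 `COc1cc(-n2ncnc2-c2ccc(SC)cc2)cc(OC)c1OC` differs from compound 1 by methylsulfanyl in place of isopropoxy on an aromatic carbon. Within the data shown here, no measured step bears on this change, so the expected result is a small step at most, a 1.9-fold lower number from compound 1 to compound 4 (0.27 log units; within the scatter). The estimate for compound 4 in this assay is 350 nM, with a range from 80 nM to 1500 nM.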

Compound 4, half-maximal inhibitory concentration: 50 nM
Estimate against measurement, compound 4: 7.0-fold (0.85 log units) above, and the stated range ends above it.
By their numbers in this assay, from the lowest: compounds 4 and 3 (each within the scatter of the next); then compound 1. At a limit, above all of these: compound 2.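

In this assay, methylsulfanyl in place of isopropoxy on an aromatic carbon, para to a large group, gives a 13-fold lower number from compound 1 to compound 4 (1.11 log units; beyond the scatter) and so shows that this position responds strongly to the change of group. The earlier step concerned the aromatic nitrogen and said nothing about this site. Nothing shown gives a reason for the size of this step.

With a single pair at this position, no trend can be drawn. Going by these compounds, how an amine, a carboxylic acid or a longer alkylsulfanyl chain would fare at this position remains open.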